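A few compounds are considered here, and "the series" means these few. Any claim that something is new, unique, unknown or untested is made for them only; others in the source may bear on it.

Three compounds have been measured in a functional assay, read by spectrophotometry, with a stated time of 2 h, tested at 0.5 mg/mL; a higher number here means a stronger effect of the compound at the concentration tested, a lower number a weaker effect:

compound 1 `CC(C)[C@@H]1CC[C@@H](C)C[C@@]12N(C)C(=O)[C@@H]1[C@H]3C(=O)N(c4ccccc4)C(=O)[C@H]3ON12` gives 28.7%
compound 2 `CC(C)[C@@H]1CC[C@@H](C)C[C@@]12N(C)C(=O)[C@@H]1[C@H]3C(=O)N(c4ccc(Cl)cc4)C(=O)[C@H]3ON12` gives 47.5%
compound 3 `COc1ccc(N2C(=O)[C@H]3[C@H](ON4[C@@H]3C(=O)N(C)[C@@]43C[C@H](C)CC[C@H]3C(C)C)C2=O)cc1` gives 44.5%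

Compound 3 stands second highest of these three numbers. Its nearest neighbour is compound 2, and a number 3 percentage points lower from compound 2 to compound 3 (within the scatter) lies within the scatter; its furthest is compound 1, from which a number 15.8 percentage points higher from compound 1 to compound 3 (beyond the scatter) lies beyond it.

Compound 4 `Cc1ccc(N2C(=O)[C@H]3[C@H](ON4[C@@H]3C(=O)N(C)[C@@]43C[C@H](C)CC[C@H]3C(C)C)C2=O)c(C)c1` is the next candidate. It differs from compound 3 in one place: 2,4-dimethylphenyl in place of 4-methoxyphenyl on an amide-type nitrogen in a ring.

Among the compounds with values here, two steps bear on this change. a number 18.8 percentage points higher from compound 1 to compound 2 (beyond the scatter) and a number 15.8 percentage points higher from compound 1 to compound 3 (beyond the scatter) both show a modest rise once the ring carries a group, while a number 3 percentage points lower from compound 2 to compound 3 (within the scatter) shows that exchanging one group for another changed little. Within the data shown here, no measured step exchanges methoxy for two methyls, so the expectation is a step within the scatter, a number 2.5 percentage points lower from compound 3 to compound 4 (within the scatter).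

Compound 4 is therefore estimated at 42%, in a range from 25% to 58%.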

Compound 4, a percentage reported as activity, at one concentration (the size of the read-out at that concentration, not a potency): 51%
Compound 4: the middle estimate sits 9 percentage points below what was measured; measured number inside the range.
By their numbers in this assay, from the lowest: compound 1; then compounds 3, 2 and 4 (each within the scatter of the next).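

In this assay, a ring with two methyl groups does as well at this position as one with a single chloro or methoxy group: a number 6.5 percentage points higher from compound 3 to compound 4 (within the scatter) and a number 3.5 percentage points higher from compound 2 to compound 4 (within the scatter) are both small, whereas a number 22.3 percentage points higher from compound 1 to compound 4 (beyond the scatter) is a real gain over plain phenyl. The rise therefore does not depend on the hydrogen-bond acceptor that leaves with 4-methoxyphenyl. Nothing available explains why adding groups to this ring raises the number. Which of the two methyls matters remains open. So does whether an amine, a carboxylic acid or a longer chain on the ring would keep this level.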